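Trimethoxybenzoyl hydrazones: moving a chlorine on the aryl ring

The source may hold more compounds than are shown below. What is called first, only, known or untested is meant among the compounds shown, and "the series" means these compounds.

Measured so far:
compound 1 `COc1cc(C(=O)N/N=C/c2ccccc2F)cc(OC)c1OC`: 51.6%
compound 2 `COc1cc(C(=O)N/N=C/c2ccc(Cl)c(Cl)c2)cc(OC)c1OC`: 29.6%

Both were tested in a functional assay on BGC-823 cells (Homo sapiens) for antiproliferative activity, read by MTT assay, tested at 1 uM; a higher number here means a stronger effect of the compound at the concentration tested, a lower number a weaker effect. Compound 1 gives 51.6%, and compound 2 gives 29.6%. Compound 2 stands lowest of the two numbers; its nearest neighbour is compound 1, with the step of a number 22 percentage points lower from compound 1 to compound 2 (beyond the scatter), beyond the scatter.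

Compound 3 `COc1cc(C(=O)N/N=C/c2cc(Cl)cc(Cl)c2)cc(OC)c1OC` is not yet measured. Its difference from compound 2 is 3,5-dichlorophenyl in place of 3,4-dichlorophenyl on a carbon with a double bond to nitrogen.

Among the compounds with values here, no measured step swaps one dichlorophenyl pattern for another; the only step known, a number 22 percentage points lower from compound 1 to compound 2 (beyond the scatter), replaces one aryl group by a different one entirely and so bears on the present change only loosely. Within the data shown here, with no closer precedent, the expected step of a number 0.4 percentage points higher from compound 2 to compound 3 (within the scatter) is small and may lie within the scatter. Compound 3 is therefore estimated at 30%, with a range from 14% to 48%.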

Compound 3, a percentage reported as inhibition, at one concentration (the size of the read-out at that concentration, not a potency): -7.5%
Estimate against measurement, compound 3: 37.5 percentage points above; measured number outside the range, below it.
By their numbers in this assay, from the lowest: compound 3; then compound 2; then compound 1.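

In this assay, the arrangement of the two chlorines on the aryl ring matters in its own right: with the same atoms joined differently, 3,5-dichlorophenyl in place of 3,4-dichlorophenyl gives a number 37.1 percentage points lower from compound 2 to compound 3 (beyond the scatter). Against the 2-fluorophenyl group the same 3,5-dichlorophenyl group gives a number 59.1 percentage points lower from compound 1 to compound 3 (beyond the scatter), so compound 3 stands lowest of the three, with its steps to both others beyond the scatter. Nothing at hand bears on what lies behind this difference.

The compounds shown leave open whether the 3,5-dichlorophenyl result depends on chlorine itself or would also appear with bromine, methoxy or an amine on the ring. Also open, going by these compounds, is whether the gap between compound 2 and compound 3 holds at concentrations other than the single one tested.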